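This account rests on a few compounds, and the source may have more. Where it says the series, first, only, none or still open, it means among the compounds named here.

In a functional assay on HCT-116 cells (Homo sapiens) for cytotoxicity, read by MTT assay, with a stated time of 72 h (a higher number here means a weaker inhibitor, a lower number a stronger inhibitor), compound 1 (`COc1ncc(-c2ccc3nc(NC(=O)N4CCCC4)nn3c2)cc1NS(=O)(=O)c1ccc(F)cc1`) gives 1290 nM and compound 2 (`COc1ncc(-c2ccc3nc(NC(=O)N(C)C)nn3c2)cc1NS(=O)(=O)c1ccc(F)cc1`) gives 760 nM, so compound 2 stands level with compound 1 within the scatter. Compound 3 (`COc1ncc(-c2ccc3nc(NC(=O)NCC(=O)N4CCCC4)nn3c2)cc1NS(=O)(=O)c1ccc(F)cc1`) carries (((pyrrolidin-1-yl)carbonyl)methyl)amino in place of dimethylamino on a carbonyl carbon. Among the compounds with values here, only one measured step bears on this change. It sits on a carbonyl carbon too, with dimethylamino in place of pyrrolidin-1-yl, and it is small: a 1.7-fold lower number from compound 1 to compound 2 (0.23 log units; within the scatter). Within the data shown here, no measured compound carries the entering group, so this evidence is thin and the range must stay wide. A slight rise in the number is the tentative expectation in this assay, with the expected step being a 1.4-fold higher number from compound 2 to compound 3 (0.16 log units; within the scatter), and no change beyond the scatter is anticipated. For compound 3 the estimated value is 1100 nM, with an expected range from 350 nM to 3500 nM.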

Compound 3, half-maximal inhibitory concentration: 140 nM
Compound 3: the middle estimate sits 7.9-fold (0.90 log units) above what was measured, and the stated range ends above it.
By their numbers in this assay, from the lowest: compound 3; then compounds 2 and 1 (each within the scatter of the next).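

In this assay the group on this carbonyl carbon proved able to shift the number beyond the scatter, which the exchange of pyrrolidin-1-yl and dimethylamino had not shown: (((pyrrolidin-1-yl)carbonyl)methyl)amino gives a 5.4-fold lower number from compound 2 to compound 3 (0.73 log units; beyond the scatter) and a 9.2-fold lower number from compound 1 to compound 3 (0.96 log units; beyond the scatter). Compound 3 therefore has the lowest number of the three, and its entering group, unlike dimethylamino, holds a hydrogen-bond donor and a hydrogen-bond acceptor as well as a five-membered non-aromatic ring. No measurement shown here accounts for this step.

The compounds shown leave open which part of the entering group goes with the lower number, the amide hydrogen, the added carbonyl or the pyrrolidine ring. Going by these compounds, whether a plain methylamino group, a morpholine amide or a carboxylic acid at the end of the chain would give a similar number also remains open.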